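A few compounds are considered here, and "the series" means these few. Any claim that something is new, unique, unknown or untested is made for them only; others in the source may bear on it.

Among the compounds with values here, compound 1 `CCC(CO)NC(=O)c1cc2cc(Br)ccc2oc1=N` is one of two compounds measured in an assay on HEK293 cells for displacement of a labelled ligand from adenosine receptor A2b (Homo sapiens), read by scintillation counting, with a stated time of 30 min, tested at 10 uM; on this read-out higher numbers stand for more inhibition at the one concentration tested (going by the name of the read-out) and lower numbers for less inhibition. In this assay compound 1 gives 4%. Within the data shown here, its one measured partner, compound 2 `CCC(CO)NC(=O)c1cc2cc(Cl)ccc2oc1=N`, gives 9% in this assay, and the single step recorded, a number 5 percentage points higher from compound 1 to compound 2 (within the scatter), is a chloro in place of bromo on an aromatic carbon that leaves the number within the scatter. Compound 3 `N=c1oc2ccc(Br)cc2cc1C(=O)NCCCO` has not yet been measured. It differs from compound 1 by 3-hydroxypropyl in place of 1-(hydroxymethyl)propyl on an amide-type nitrogen. Among the measured compounds shown here, no measured step touches the group on the amide-type nitrogen, so nothing among the data speaks for a change beyond the scatter in this assay; the one step that exists is the halogen swap, and it was small. Compound 3 is therefore expected to give about 6%, with a range from 0% to 20%. This estimate means a step of a number 2 percentage points higher from compound 1 to compound 3 (within the scatter), expected to stay within the scatter.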

Compound 3, a percentage reported as inhibition, at one concentration (the size of the read-out at that concentration, not a potency): 25%
For compound 3 the middle estimate is 19 percentage points below the measured one; measured number outside the range, above it.
By their numbers in this assay, from the lowest: compounds 1 and 2 (each within the scatter of the next); then compound 3.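

The group on the amide-type nitrogen turns out to be a place where the read-out can move in this assay, which the halogen swap alone could not show: 3-hydroxypropyl in place of 1-(hydroxymethyl)propyl gives a number 21 percentage points higher from compound 1 to compound 3 (beyond the scatter) on the same bromo core. The two groups match in their hydrogen-bond donors and acceptors and both carry no net charge, yet the entering group has 4 heavy atoms against 5 and keeps its hydroxyl on a chain without the ethyl-bearing branch of the leaving group. Nothing available explains why this change raises the number.

The compounds shown leave open whether the same exchange would raise the number on the chloro compound 2 as well. They also leave open whether a longer chain, or an amine or a carboxylic acid in place of the hydroxyl, would carry the number further.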